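Fluoro for methoxy on the aryl group of compound 1

A few compounds are considered here, and "the series" means these few. Any claim that something is new, unique, unknown or untested is made for them only; others in the source may bear on it.

Compound 1 `CCOC(=O)c1c(-c2cccc(OC)c2)[nH]c2cc(OC)ccc2c1=O` gives no number in an ADME assay on Raji cells (Homo sapiens) for cytotoxicity, read by luminescence, with a stated time of 72 h; on this read-out lower numbers stand for an effect already at smaller amounts and higher numbers for an effect only at larger amounts of compound: compound 1 reads > 21500 nM, a limit of the assay. Compound 2 `CCOC(=O)c1c(-c2cccc(OCC(C)C)c2)[nH]c2cc(OC)ccc2c1=O` likewise reads > 21500 nM in this assay, again a limit. The step that the two limits leave unreadable from compound 1 to compound 2 is therefore not readable, as the limit of > 21500 nM in this assay, at which 2 of the 2 values shown sit, shows. Compound 3 `CCOC(=O)c1c(-c2cccc(F)c2)[nH]c2cc(OC)ccc2c1=O` differs from compound 1 by fluoro in place of methoxy on an aromatic carbon. Within the data shown here, no measured step bears on this change, and both values so far sit at the limit. Compound 3 is expected to give 30000 nM (range 8000 nM to 120000 nM) in this assay, most probably once more as a limit. The expected step that the limit leaves unreadable from compound 1 to compound 3 is estimated as none beyond the scatter.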

Compound 3, half-maximal effective concentration: > 21500 nM
Compound 3: only a limit was reported; the forecaster's own chance of this, stated with the estimate: 75%; the middle value lies beyond the limit too.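

In this assay no step among compound 1, compound 2 and compound 3 can be read: the limit of > 21500 nM in this assay, at which 3 of the 3 values shown sit.

Still open, going by these compounds, is where compound 1, compound 2 and compound 3 truly lie on this read-out, and whether any change at this aryl position shifts the value.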